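The source may report more compounds than this note shows. Statements on the series, on what has been measured and on what is new or still open speak of the compounds shown alone.

Of the compounds shown here, three sharing one core have been measured in an assay on isolated protein (Cricetulus griseus) for inhibition of Monoamine oxidase (Homo sapiens); on this read-out higher numbers stand for weaker inhibition and lower numbers for stronger inhibition. Compound 1 `CCOc1ccc2c(=O)c(-c3ccc(O)cc3)coc2c1` gives 300 nM. Compound 2 `O=c1c(-c2ccc(O)cc2)coc2cc(OCCCCCCBr)ccc12` gives 2000 nM. Compound 3 `O=c1c(-c2ccc(O)cc2)coc2cc(OCCCBr)ccc12` gives 150 nM, the lowest number of the three; its gap to compound 1 lies within the scatter, while its gap to compound 2 lies beyond it. Compound 4 `O=C(O)CCCCCCCCCOc1ccc2c(=O)c(-c3ccc(O)cc3)coc2c1` has not yet been measured. It differs from compound 3 by 6-carboxyhexyl in place of bromo on a saturated chain carbon, three bonds along the chain from an oxygen on an aromatic ring. Among the measured compounds shown here, two measured steps bear on this change, both concerning the length of the chain on the aromatic oxygen. Making that chain longer gave a 6.7-fold higher number from compound 1 to compound 2 (0.82 log units; beyond the scatter), and making it shorter gave a 13-fold lower number from compound 2 to compound 3 (1.12 log units; beyond the scatter), whereas the small step of a 2.0-fold lower number from compound 1 to compound 3 (0.30 log units; within the scatter) stayed within the scatter. In the compounds measured, the longer chain went with weaker inhibition, and compound 4 carries a chain longer still, ending in a carboxylic acid. A step toward weaker inhibition, beyond the scatter, is therefore expected. The expected step is a 20-fold higher number from compound 3 to compound 4 (1.30 log units; beyond the scatter). Compound 4 is thus estimated to give 3000 nM, with a likely range from 700 nM to 13000 nM.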

Compound 4, half-maximal inhibitory concentration: 10000 nM
Beside the measured number, compound 4's estimate is 3.3-fold (0.52 log units) below it, and the stated range covers the measured number.
By their numbers in this assay, from the lowest: compounds 3 and 1 (each within the scatter of the next); then compound 2; then compound 4.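

In this assay, 6-carboxyhexyl in place of bromo gave a 67-fold higher number from compound 3 to compound 4 (1.82 log units; beyond the scatter), the largest step yet seen at this position. The weakening continues past the long bromo chain, with a 5.0-fold higher number from compound 2 to compound 4 (0.70 log units; beyond the scatter) and a 33-fold higher number from compound 1 to compound 4 (1.52 log units; beyond the scatter), so among compounds 1, 2 and 4 the number rises as the chain grows, while compound 3 sits within the scatter of compound 1 despite its bromo-ended chain. No measurement here explains the loss of inhibition.

Chain length and chain end change together in these steps, so the compounds shown leave open how much of the rise belongs to the added length and how much to the carboxylic acid. A carboxylic acid on a short chain, or a bromo on a chain as long as that of compound 4, would separate the two.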